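The source may hold more compounds than are shown below. What is called first, only, known or untested is meant among the compounds shown, and "the series" means these compounds.

For the measured compounds named here, in a physicochemical assay, read by spectrophotometry, with a stated time of 30 min (a lower number here means a stronger inhibitor, a higher number a weaker inhibitor), compound 1 `O=C(CCc1nc2ccccc2c(=O)[nH]1)N/N=C/c1ccc(O)c(O)c1` gives 113000000 nM, the lower of the two numbers measured so far. Compound 2 `O=C(CCCc1nc2ccccc2c(=O)[nH]1)N/N=C/c1ccc(Cl)cc1` gives 353000000 nM, and the gap between the two lies beyond the usual scatter. Compound 3 `O=C(CCc1nc2ccccc2c(=O)[nH]1)N/N=C/c1ccccc1` has not yet been measured. It differs from compound 1 in one place, with phenyl in place of 3,4-dihydroxyphenyl on a carbon with a double bond to nitrogen. Going by the values given here, no measured pair shows this change on its own, so the guidance is thin. Though it differs from compound 1 in other places too, compound 2 also lacks the 3,4-dihydroxyphenyl group and reads 353000000 nM. A move toward a higher number, meaning a weaker inhibitor, is therefore expected, an estimated step of a 2.7-fold higher number from compound 1 to compound 3 (0.42 log units; beyond the scatter). For compound 3 the estimate is 300000000 nM, with an expected range of 120000000 nM to 800000000 nM.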

Compound 3, half-maximal inhibitory concentration: 734000000 nM
The estimate for compound 3 lay 2.4-fold (0.39 log units) below the measured number; measured number inside the range.
By their numbers in this assay, from the lowest: compound 1; then compound 2; then compound 3.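

For the compounds shown here, this is the first comparison that changes only this position, the carbon with a double bond to nitrogen. In this assay, putting phenyl in place of 3,4-dihydroxyphenyl gives a 6.5-fold higher number from compound 1 to compound 3 (0.81 log units; beyond the scatter) with the rest of the molecule unchanged, so the 3,4-dihydroxyphenyl group of compound 1 is linked to the stronger inhibition. The six-membered aromatic ring of carbon stays in both compounds, which ties the step to the loss of the hydroxyl groups rather than of the ring, though nothing available explains how these groups act.

The compounds shown do not reveal whether a single hydroxyl group would keep the stronger reading, or whether methoxy or an amine could replace the hydroxyl groups on the ring. As far as these compounds go, the effect of a longer chain on its own also stays open, since compound 2 differs from compound 1 and compound 3 in more than one place.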